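Piperidinylmethyl for dimethylaminomethyl in an EP2 antagonist series

The source may hold more compounds than are shown below. What is called first, only, known or untested is meant among the compounds shown, and "the series" means these compounds.

Compound 1 `COc1cccc(/C=C/C(=O)NCCn2c(C)cc3ccccc32)c1` gives 29.2 nM in an assay on C6 cells for antagonist activity at prostaglandin E2 receptor EP2 subtype (Homo sapiens), read by TR-FRET, with stated times of 10 min and 40 min, tested at 1 uM; on this read-out higher numbers stand for weaker inhibition and lower numbers for stronger inhibition.
Compound 2 `COc1cc(/C=C/C(=O)NCCN2CCCCC2C)cc(OC)c1OC` gives > 1000 nM in this assay, a limit of the assay and not a number.
Compound 3 `COc1cc(/C=C/C(=O)NCCn2c(C)c(CN(C)C)c3ccccc32)cc(OC)c1OC` gives > 1000 nM in this assay, again a limit and not a number.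

Compound 3 therefore stands at the limit, and the limit of > 1000 nM in this assay, at which 2 of the 3 values shown sit, shows how common that outcome is among the three values. Compound 4 `COc1cc(/C=C/C(=O)NCCn2c(C)c(CN3CCCCC3)c3ccccc32)cc(OC)c1OC` differs from compound 3 by piperidin-1-yl in place of dimethylamino on a saturated chain carbon bound to an aromatic carbon. For the measured compounds named here, with no measured step of this kind to lean on, and with compound 3 itself only a limit, the step is expected to be none beyond the scatter: a step that the limit leaves unreadable from compound 3 to compound 4. Compound 4 is estimated at 1500 nM in this assay, with a range from 500 nM to 5000 nM, and most likely another limit.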

Compound 4, antagonist equilibrium constant in the prostaglandin E2 receptor EP2 subtype assay: > 1000 nM
Compound 4 gave a limit, no number; the forecaster's own chance of this, stated with the estimate: 75%; the middle value lies beyond the limit too.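

In the prostaglandin E2 receptor EP2 subtype assay compound 3 gives > 1000 nM, a limit of the assay and not a number. In the prostaglandin E2 receptor EP2 subtype assay compound 4 gives > 1000 nM, again a limit and not a number.

Compound 3 and compound 4 both stand at a limit in the prostaglandin E2 receptor EP2 subtype assay, not at a number, so no step can be read between them: the limit of > 1000 nM in the prostaglandin E2 receptor EP2 subtype assay, at which 3 of the 4 values shown sit.

From the compounds shown here alone, whether piperidin-1-yl in place of dimethylamino shifts this read-out at all stays open.

In a physicochemical assay for solubility, read by nephelometry, in phosphate buffer, at pH 7.4 (on this read-out lower numbers stand for lower solubility and higher numbers for higher solubility), compound 3 gives 110000 nM. In the physicochemical assay compound 4 gives 75000 nM. In the physicochemical assay the step reads a 1.5-fold lower number from compound 3 to compound 4 (0.17 log units; within the scatter).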